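Triazole series: removing one hydroxy from compound 1

The source may report more compounds than this note shows. Statements on the series, on what has been measured and on what is new or still open speak of the compounds shown alone.

compound 1 `COC(=O)c1cc(-n2cc(-c3cc(O)ccc3O)nn2)ccc1O`: 52%
compound 2 `COc1cc(OC)cc(-c2cn(-c3ccc(O)c(C(=O)O)c3)nn2)c1`: 9%
compound 3 `O=C(OCCCc1ccccc1)c1cc(-n2cc(-c3cc(O)ccc3O)nn2)ccc1O`: 81%

In a functional assay on CCRF-CEM cells (Homo sapiens) for inhibition, read by MTT assay, with a stated time of 2 days, tested at 10 uM (a higher number here means more inhibition at the concentration tested (going by the name of the read-out), a lower number less inhibition), compound 1 gives 52%, the second highest of the three numbers. The nearest is compound 3 with 81%, a change that reads a number 29 percentage points higher from compound 1 to compound 3 (beyond the scatter) (beyond the scatter). Within the data shown here, the furthest is compound 2 with 9%, well below compound 1, though compound 2 differs from compound 1 in more than one place and no single step links them.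

Compound 4 `COC(=O)c1cc(-n2cc(-c3cccc(O)c3)nn2)ccc1O` differs from compound 1 by hydrogen in place of hydroxy on an aromatic carbon. Among the measured compounds shown here, the one measured step, a number 29 percentage points higher from compound 1 to compound 3 (beyond the scatter), alters the ester chain and leaves the aromatic ring untouched, so it does not bear on this change; no measured step touches the ring. Without a guiding step, only a modest fall is expected, a number 14 percentage points lower from compound 1 to compound 4 (beyond the scatter). Compound 4 is therefore estimated at 38%, within 15% to 62%.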

Compound 4, a percentage reported as inhibition, at one concentration (the size of the read-out at that concentration, not a potency): 5%
Beside the measured number, compound 4's estimate is 33 percentage points above it; the measured number lies below the stated range.
By their numbers in this assay, from the lowest: compounds 4 and 2 (each within the scatter of the next); then compound 1; then compound 3.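

Replacing hydroxy with hydrogen, 2,5-dihydroxyphenyl to 3-hydroxyphenyl, gives a number 47 percentage points lower from compound 1 to compound 4 (beyond the scatter) in this assay. The earlier step changed only the ester chain; this one shows that inhibition at the tested concentration is sensitive to a single change on the aromatic ring, and that this hydroxy cannot be lost without a large fall. No evidence on the reason for this fall is available.

As far as these compounds go, whether an amine or a fluorine at this carbon would retain the inhibition of compound 1 stays open. Also open, from the compounds shown here alone, is whether losing this hydroxy costs as much with the longer ester chain of compound 3.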